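A few compounds are considered here, and "the series" means these few. Any claim that something is new, unique, unknown or untested is made for them only; others in the source may bear on it.

Measured so far in a functional assay on BXPC-3 cells (Homo sapiens) for antiproliferative activity, read by MTT assay, with a stated time of 24 h; on this read-out higher numbers stand for weaker inhibition and lower numbers for stronger inhibition:
compound 1 `CCn1c(C(=O)NCCC(=O)OC)ccc1C(CC)(CC)c1ccc(OCS(=O)(=O)c2ccccc2)c(C)c1`: > 50000 nM, a limit of the assay.
compound 2 `CCn1c(C(=O)N[C@@H](C)CO)ccc1C(CC)(CC)c1ccc(OCS(=O)(=O)c2ccccc2)c(C)c1`: 15300 nM.
compound 3 `CCn1c(C(=O)NC2(C(=O)O)CC2)ccc1C(CC)(CC)c1ccc(OCS(=O)(=O)c2ccccc2)c(C)c1`: > 50000 nM, a limit of the assay.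

Compound 2 stands apart as the only one of the three that returns a number in this assay; the other two sit at the limit of > 50000 nM in this assay, at which 2 of the 3 values shown sit. Between them, an at least 3.2-fold lower number from compound 1 to compound 2 (0.51 log units; beyond the scatter), with 1-(hydroxymethyl)ethyl in place of 2-(methoxycarbonyl)ethyl on the amide-type nitrogen, and an at least 3.2-fold higher number from compound 2 to compound 3 (0.51 log units; beyond the scatter), with 1-carboxycyclopropyl in place of 1-(hydroxymethyl)ethyl. The step from compound 1 to compound 3 cannot be read, a step that the two limits leave unreadable from compound 1 to compound 3.

Compound 4 `CCn1c(C(=O)N[C@H](C(=O)O)C(C)C)ccc1C(CC)(CC)c1ccc(OCS(=O)(=O)c2ccccc2)c(C)c1` has not been measured. It differs from compound 2 in one place: 1-carboxy-2-methylpropyl in place of 1-(hydroxymethyl)ethyl on an amide-type nitrogen. The entering 1-carboxy-2-methylpropyl, like the 1-carboxycyclopropyl of compound 3, carries a carboxy group, and the hydroxymethyl of compound 2 leaves. The step from compound 2 to compound 3 is the one that bears on this change, and it was at least modest and upward. A step of similar direction and size is expected in this assay, with a fair chance that only a limit is returned.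

Compound 4 is therefore expected at 40000 nM, range 15000 nM to 100000 nM, an expected step of a 2.6-fold higher number from compound 2 to compound 4 (0.42 log units; beyond the scatter).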

Compound 4, half-maximal inhibitory concentration: 16200 nM
Compound 4: middle estimate off by 2.5-fold (0.39 log units), on the high side; measured number inside the range.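

In this assay a carboxy group on the amide-type nitrogen is compatible with a measurable number, which compound 3 alone could not show: a 1.1-fold higher number from compound 2 to compound 4 (0.02 log units; within the scatter), so 1-carboxy-2-methylpropyl and 1-(hydroxymethyl)ethyl cannot be told apart here. The carboxy group therefore does not decide the outcome on its own, and what carries it counts, with an at least 3.0-fold lower number from compound 3 to compound 4 (0.48 log units; beyond the scatter) for 1-carboxy-2-methylpropyl in place of 1-carboxycyclopropyl, and an at least 3.0-fold lower number from compound 1 to compound 4 (0.48 log units; beyond the scatter) for 1-carboxy-2-methylpropyl in place of 2-(methoxycarbonyl)ethyl. Both of these steps start from a limit, so each gives only a lower bound on its size, and the step from compound 1 to compound 3 cannot be read: the limit of > 50000 nM in this assay, at which 2 of the 4 values shown sit.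

Open, on these data alone, is whether a smaller 1-carboxyethyl group, a longer carboxyalkyl chain or an amine on the same nitrogen would hold the number of compound 4 or fall to the limit. Also open, as far as these compounds go, is whether the opposite configuration at the defined stereocentre of 1-carboxy-2-methylpropyl reads the same in this assay.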